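The compounds below may be only part of what the source reports. "The series", "measured", "known", "first", "only" and "open" are said of these compounds alone.

Compound 2 `Cc1cc2cc(N/C=C\C(=O)c3nc(-c4ccc(F)cc4)n4ccccc34)ccc2[nH]1` carries a 2-methyl-1H-indol-5-yl group on the amine nitrogen of the shared core. In a functional assay on B16-F10 cells (Mus musculus) for cytotoxicity, read by MTT assay, with a stated time of 48 h (a higher number here means a weaker inhibitor, a lower number a stronger inhibitor), compound 2 gives > 30000 nM, which is a limit of the assay and not a number. Compound 1 `COc1ccc(-c2nc(C(=O)/C=C\Nc3ccc(F)cc3)c3ccccn23)cc1` returns > 30000 nM in this assay, again a limit. Compound 3 `O=C(/C=C\Nc1ccc2cc[nH]c2c1)c1nc(-c2ccc(C(F)(F)F)cc2)n2ccccc12` returns > 30000 nM in this assay, also a limit. Among the measured compounds shown here, compound 2 therefore stands where every measured value stands, at the limit of > 30000 nM in this assay, at which 3 of the 3 values shown sit; no value shown is a real number, and no step between measured compounds can be drawn.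

Compound 4 `O=C(/C=C\Nc1ccc(Cl)cc1)c1nc(-c2ccc(F)cc2)n2ccccc12` is the next member. The change from compound 2: 4-chlorophenyl in place of 2-methyl-1H-indol-5-yl on an amine nitrogen. The values of compound 1 and compound 2 are both limits, so the shown data give no direction for a change of this kind. Compound 1, with 4-fluorophenyl at the same place, gives only the limit > 30000 nM, and compound 4 is expected to behave alike. The expected step that the limit leaves unreadable from compound 2 to compound 4 is none beyond the scatter. Compound 4 is estimated at 45000 nM in this assay, within 15000 nM to 150000 nM, and most likely reported only as a limit.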

Compound 4, half-maximal inhibitory concentration: 11000 nM
The estimate for compound 4 lay 4.1-fold (0.61 log units) above the measured number; measured number outside the range, below it.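

In this assay, the place on the amine nitrogen proves able to move the series off the assay limit: 4-chlorophenyl in place of 2-methyl-1H-indol-5-yl gives an at least 2.7-fold lower number from compound 2 to compound 4 (0.43 log units; beyond the scatter). Compound 4, at 11000 nM, holds the only real number among the compounds shown, so this is the first readable direction for a change at this place. The step has only a lower bound, and the rest of the series gives no further number to set beside it: the limit of > 30000 nM in this assay, at which 3 of the 4 values shown sit.

Going by these compounds, it remains open whether the step follows from the chlorine or from the loss of the two-ring indole group, as this one change alters both. A plain phenyl or a 4-bromophenyl on the same amine nitrogen would help separate the two, and a 4-aminophenyl would test how far the place tolerates an amine.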